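The source may hold more compounds than are shown below. What is called first, only, known or untested is meant among the compounds shown, and "the series" means these compounds.

Compound 1 `CCN(CC)CCN(C)Cc1c(C(C)(C)C)nc2n(Cc3ccccc3F)c(C)c(-c3cccc(OC)c3)c(=O)n12`: 260 nM
Compound 2 `COc1cccc(-c2c(C)n(Cc3ccccc3F)c3nc(C(C)(C)C)c(CN(C)Cc4ccccc4)n3c2=O)c1`: 72 nM
Compound 3 `COc1cccc(-c2c(C)n(Cc3ccccc3F)c3nc(C(C)(C)C)c(CN(C)Cc4ccccn4)n3c2=O)c1`: 11 nM

These three were measured in an assay on isolated protein for binding affinity to Gonadotropin-releasing hormone receptor (Homo sapiens); on this read-out higher numbers stand for weaker inhibition and lower numbers for stronger inhibition. Compound 3 stands at the lowest number of the three; its nearest neighbour is compound 2, separated by a 6.5-fold lower number from compound 2 to compound 3 (0.82 log units; beyond the scatter), and the furthest is compound 1, separated by a 24-fold lower number from compound 1 to compound 3 (1.37 log units; beyond the scatter). The remaining step, a 3.6-fold lower number from compound 1 to compound 2 (0.56 log units; beyond the scatter), completes the set. Compound 4 `COC(=O)C(C)(C)c1nc2n(Cc3ccccc3F)c(C)c(-c3cccc(OC)c3)c(=O)n2c1CN(C)Cc1ccccn1` has not yet been measured. It differs from compound 3 by methoxycarbonyl in place of methyl on a saturated chain carbon bound to an aromatic carbon and two saturated chain carbons. Within the data shown here, none of the measured steps touches this part of the molecule; all three change the group on the saturated chain carbon bound to an amine nitrogen. So no measured step bears directly on the present change, and the expectation rests on the shared core alone. The step expected here, a 1.8-fold higher number from compound 3 to compound 4 (0.26 log units; within the scatter), is small, probably within the scatter. Compound 4 is estimated at 20 nM, with a range from 5 nM to 80 nM.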

Compound 4, inhibition constant: 4.2 nM
Compound 4: middle estimate off by 4.8-fold (0.68 log units), on the high side; measured number below the stated range.
By their numbers in this assay, from the lowest: compound 4; then compound 3; then compound 2; then compound 1.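

Replacing one methyl of the tert-butyl group with methoxycarbonyl gives a 2.6-fold lower number from compound 3 to compound 4 (0.42 log units; beyond the scatter) in this assay. This position, on a saturated chain carbon bound to an aromatic carbon and two saturated chain carbons, therefore accepts a larger group that brings hydrogen-bond acceptors, and the number falls rather than rises. Nothing available explains this gain.

Going by these compounds, whether the whole methoxycarbonyl group is needed remains open, and a carboxylic acid or a longer chain in its place would test this. Also open, on these data alone, is whether the same swap gives a similar step in compound 2.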